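A few compounds are considered here, and "the series" means these few. Any claim that something is new, unique, unknown or untested is made for them only; others in the source may bear on it.

In a functional assay on the whole organism for inhibition, with Cavia porcellus as the target, with stated times of 1 h and 10 min, at a dose of 0.3 mg/kg by the oral route (a higher number here means a stronger effect of the compound at the dose given, a lower number a weaker effect), compound 1 `Cc1c(CCCC(=O)O)c2cccc(/C=C/c3ccc(OCCCCc4c(F)cc(F)c(F)c4F)cc3)c2n1CC(=O)O` gives 87%, the higher of the two numbers seen so far. Compound 2 `Cc1c(F)cccc1CCCCOc1ccc(/C=C/c2cccc3c(CCCC(=O)O)cn(CC(=O)O)c23)cc1` gives 73%, a gap from compound 1 that lies beyond the usual scatter. Compound 3 `Cc1c(CCCC(=O)O)c2cccc(/C=C/c3ccc(OCCCCc4cc(F)c(F)c(F)c4F)cc3)c2n1CC(=O)O` has not yet been measured. Its difference from compound 1 reads: 2,3,4,5-tetrafluorophenyl in place of 2,3,4,6-tetrafluorophenyl on a saturated chain carbon, four bonds along the chain from an oxygen on an aromatic ring. Going by the values given here, no step between measured compounds shares this change, so nothing seen bears on its size; the same atoms are merely joined differently, and a step within the usual scatter, in either direction, is expected. The expected step of a number 7 percentage points lower from compound 1 to compound 3 (within the scatter) is therefore small. Compound 3 is estimated to give 80%, within 60% to 95%.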

Compound 3, a percentage reported as inhibition, in the whole organism at one dose (the size of the read-out at that dose, not a potency): 55%
Compound 3: middle estimate off by 25 percentage points, on the high side, outside the stated range (below it).
By their numbers in this assay, from the lowest: compound 3; then compound 2; then compound 1.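

In this assay the placing of the fluorines on this ring proves to matter at this position: with the same atoms joined differently, 2,3,4,5-tetrafluorophenyl in place of 2,3,4,6-tetrafluorophenyl gives a number 32 percentage points lower from compound 1 to compound 3 (beyond the scatter). Going by these compounds alone, this is the first step read at this position, and it is large even though the counts printed for the two groups are identical. Nothing at hand accounts for the size of this step. Open, going by these compounds, is how pentafluorophenyl or a longer chain would read at this place, and whether the same change gives a step of this size on the core of compound 2.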